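A few compounds are considered here, and "the series" means these few. Any claim that something is new, unique, unknown or untested is made for them only; others in the source may bear on it.

Measured in a functional assay on ECa-109 cells (Homo sapiens) for inhibition, read by MTT assay, with a stated time of 72 h; a lower number here means a stronger inhibitor, a higher number a weaker inhibitor:

Compound 1, `C#CCSc1nc(Nc2cccc(C(F)(F)F)c2)c(C#N)c(-c2ccccc2)n1`: > 128000 nM, a limit of the assay.
Compound 2, `C#CCSc1nc(Nc2ccc(Cl)cc2)c(C#N)c(-c2ccccc2)n1`: > 128000 nM, a limit of the assay.
Compound 3, `N#Cc1c(Nc2cccc(C(F)(F)F)c2)nc(SCc2cn(Cc3ccccc3Cl)nn2)nc1-c1ccccc1`: 32000 nM.

Compound 3 is the only one of the three to give a number at all; the other two sit at the limit of > 128000 nM in this assay, at which 2 of the 3 values shown sit. Compound 4, `COc1ccccc1Nc1nc(SCc2cn(Cc3ccccc3Cl)nn2)nc(-c2ccccc2)c1C#N`, differs from compound 3 in one place: 2-methoxyphenyl in place of 3-(trifluoromethyl)phenyl on a nitrogen on an aromatic ring. Within the data shown here, no measured pair shows what such a change does here, so the expectation rests on compound 3 alone. The step from compound 3 to compound 4 is expected to be a 1.6-fold higher number from compound 3 to compound 4 (0.19 log units; within the scatter), that is, little beyond the scatter, with a lean toward a weaker inhibitor. Compound 4 is therefore estimated at 50000 nM in this assay, with a range from 15000 nM to 128000 nM.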

Compound 4, half-maximal inhibitory concentration: 9670 nM
Estimate against measurement, compound 4: 5.2-fold (0.71 log units) above; measured number outside the range, below it.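

In this assay, among these compounds, putting 2-methoxyphenyl in place of 3-(trifluoromethyl)phenyl on the aromatic amine nitrogen gives a 3.3-fold lower number from compound 3 to compound 4 (0.52 log units; beyond the scatter) and this is the first comparison here of compounds that differ in one place. It shows that the group on this nitrogen can change the read-out while the rest of the molecule stays fixed. Nothing measured here explains why the number falls.

Among the compounds shown here, with only two groups compared at this place, the separate contributions of the methoxy and trifluoromethyl groups remain unresolved. As far as these compounds go, how an unsubstituted phenyl or a morpholine would behave here also stays open.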